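Aryl swap at the benzylamine end of the series

A few compounds are considered here, and "the series" means these few. Any claim that something is new, unique, unknown or untested is made for them only; others in the source may bear on it.

Among the measured compounds shown here, compound 1 `O=S(=O)(NCCCNCc1ccc(Cl)c(Cl)c1)c1cc(C(F)(F)F)cc(C(F)(F)F)c1` gives 1800 nM in a functional assay on Capan-2 cells (Homo sapiens) for inhibition, read by MTT assay, with a stated time of 72 h (on this read-out higher numbers stand for weaker inhibition of growth and lower numbers for stronger inhibition of growth), the lower of the two numbers measured so far; its nearest neighbour is compound 2 `COc1ccc(CNCCCNS(=O)(=O)c2cc(C(F)(F)F)cc(C(F)(F)F)c2)cc1OC`, which gives 15000 nM in this assay. That gap is the step of an 8.3-fold higher number from compound 1 to compound 2 (0.92 log units; beyond the scatter). Compound 3 `COc1ccc(CNCCCNS(=O)(=O)c2cc(C(F)(F)F)cc(C(F)(F)F)c2)cc1` differs from compound 1 by 4-methoxyphenyl in place of 3,4-dichlorophenyl on a saturated chain carbon bound to an amine nitrogen. For the measured compounds named here, the only step that bears on this change is the one from compound 1 to compound 2, beyond the scatter and toward weaker growth inhibition; a single methoxy group is part of that change, so a step in the same direction, probably smaller, is expected here. Compound 3 is therefore estimated at 7000 nM, range 2500 nM to 20000 nM. The expected step is a 3.9-fold higher number from compound 1 to compound 3 (0.59 log units; beyond the scatter).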

Compound 3, concentration for 50% growth inhibition: 2400 nM
Compound 3: the middle estimate sits 2.9-fold (0.46 log units) above what was measured, and the stated range ends above it.
By their numbers in this assay, from the lowest: compounds 1 and 3 (each within the scatter of the next); then compound 2.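

In this assay, 4-methoxyphenyl in place of 3,4-dichlorophenyl on a saturated chain carbon bound to an amine nitrogen leaves the number within the scatter (a 1.3-fold higher number from compound 1 to compound 3 (0.12 log units; within the scatter)), so losing the two chlorines does not by itself give the drop seen with compound 2. The drop goes with the extra methoxy instead: hydrogen in its place gives a step beyond the scatter (a 6.3-fold lower number from compound 2 to compound 3 (0.80 log units; beyond the scatter)).

Still open, as far as these compounds go, is whether a hydroxy group or a nitrile in place of the methoxy of compound 3 would hold the number, and whether a longer chain would. No measurement here accounts for the effect of the extra methoxy.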